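The source may report more compounds than this note shows. Statements on the series, on what has been measured and on what is new or still open speak of the compounds shown alone.

Three hydrazone amides built on a shared core have been tested in a functional assay on cells (Splenocyte, Mus musculus, strain BALB/c) for inhibition, read by scintillation counting and thymidine incorporation, with a stated time of 72 h; on this read-out lower numbers stand for stronger inhibition and higher numbers for weaker inhibition. Compound 1 `COc1cc(C(=O)N/N=C(C)/C=N/Nc2ccc([N+](=O)[O-])cc2)ccc1O` gives 5100 nM, and compound 2 `CC(/C=N/Nc1ccc([N+](=O)[O-])cc1)=N\NC(=O)c1ccccc1I` gives 2980 nM; between them lies a 1.7-fold lower number from compound 1 to compound 2 (0.23 log units; within the scatter). Compound 3 `CC(/C=N/Nc1ccc([N+](=O)[O-])cc1)=N\NC(=O)c1ccccc1F` reaches only the limit of > 12000 nM in this assay, so no number is known for it. It stands as the weakest of the three, with an at least 2.3-fold higher number from compound 1 to compound 3 (0.37 log units; beyond the scatter) and an at least 4.0-fold higher number from compound 2 to compound 3 (0.60 log units; beyond the scatter). Compound 4 `CC(/C=N/Nc1ccc([N+](=O)[O-])cc1)=N\NC(=O)c1cccc(C)c1` carries 3-methylphenyl in place of 2-fluorophenyl on a carbonyl carbon. For the measured compounds named here, no measured step puts a methyl in place of a fluoro, so the expectation rests on the spread across compounds 1 to 3. Compound 4 is expected to come back into the measurable range, with an estimated step of an at least 2.0-fold lower number from compound 3 to compound 4 (0.30 log units; that floor lies within the scatter) and an estimated value of 6000 nM, between 2000 nM and 20000 nM.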

Compound 4, half-maximal inhibitory concentration: > 12000 nM
Compound 4 was reported as a limit (the forecaster's own chance of this, stated with the estimate: 30%); middle value at least 2.0-fold (0.30 log units) away from the limit.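

On the carbonyl carbon, 3-methylphenyl joins 2-fluorophenyl as a second group that gives no readable number, and the step between compound 3 and compound 4 cannot be read, since both rest on a limit: the limit of > 12000 nM in this assay, at which 2 of the 4 values shown sit. Compound 4 stands clearly apart from the two compounds with measured values, with an at least 4.0-fold higher number from compound 2 to compound 4 (0.60 log units; beyond the scatter) and with an at least 2.3-fold higher number from compound 1 to compound 4 (0.37 log units; beyond the scatter). So far, only 2-iodophenyl and 4-hydroxy-3-methoxyphenyl give numbers at this place.

Any order between compound 3 and compound 4 stays open. Also open, going by these compounds, is what a phenyl ring carrying an amine or a carboxylic acid would give here.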